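Carbamoyl for Carboxy, Carried to a Second Core

The source may hold more compounds than are shown below. What is called first, only, known or untested is meant among the compounds shown, and "the series" means these compounds.

Compound 1 `C=C1[C@@H](CC(=O)O)[C@H]1CCCC` and compound 2 `C=C1[C@@H](CC(N)=O)[C@H]1CCCC` share one core and differ in a single place: amino in place of hydroxy on a carbonyl carbon. In a functional assay (Hepatocyte) for inhibition, with Rattus norvegicus as the target (a lower number here means a stronger inhibitor, a higher number a weaker inhibitor), compound 1 gives 15000 nM, and compound 2 gives 4000 nM. That change produced a 3.8-fold lower number from compound 1 to compound 2 (0.57 log units; beyond the scatter).

Compound 3 `C=C1[C@@H](CC(=O)O)[C@H]1CCCCCCCCCCCC` carries the carboxy group on a second core; the difference between the core of compound 1 and the core of compound 3 is not broken down here. In this assay compound 3 gives 25000 nM. Its gap to compound 1 lies within the scatter of this kind of measurement, while its gap to compound 2 lies beyond it.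

Compound 4 `C=C1[C@@H](CC(N)=O)[C@H]1CCCCCCCCCCCC` has not yet been measured in this assay. It stands to compound 3 as compound 2 stands to compound 1: the change is amino in place of hydroxy on a carbonyl carbon, and the place is described in the same words for both pairs, so it is the same change, here seen on a second core. For the measured compounds named here, only one earlier instance of it is available, so the expectation rests on that alone: the author expects the step to repeat in size because of a 3.8-fold lower number from compound 1 to compound 2 (0.57 log units; beyond the scatter). The expected step from compound 3 is a 3.6-fold lower number from compound 3 to compound 4 (0.55 log units; beyond the scatter). Compound 4 is therefore estimated at 7000 nM in this assay, with an expected range from 2500 nM to 18000 nM.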

Compound 4, half-maximal inhibitory concentration: 32000 nM
Compound 4: middle estimate off by 4.6-fold (0.66 log units), on the low side; measured number above the stated range.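

In this assay, the exchange of hydroxy for amino on a carbonyl carbon gives a 1.3-fold higher number from compound 3 to compound 4 (0.11 log units; within the scatter), so on the core of compound 3 this step cannot be told from the scatter, whereas on the core of compound 1 it lies beyond it. The size of the step therefore did not carry from one core to the other, and the earlier pair proved a poor guide to the later one: the same change on two cores in this assay, a 3.8-fold lower number (0.57 log units; beyond the scatter) from compound 1 to compound 2 and a 1.3-fold higher number (0.11 log units; within the scatter) from compound 3 to compound 4, 4.8-fold (0.68 log units) apart, beyond the scatter of two such steps

For the compounds shown here, with only two pairs, this shows that the outcome of the change depends on the core in this assay, but it does not show which feature of the two cores is responsible, why the steps part, or how the change would behave on any third core.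

The compounds shown leave open whether a chain of intermediate length, or one shorter than that of compound 1, would give a step like the one on the core of compound 1 or the one on the core of compound 3. They also leave open how an ester or a nitrile in place of the carboxy or carbamoyl group would read on these two cores.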